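Sulfur substituent swap on the compound 1 core

The compounds below may be only part of what the source reports. "The series", "measured", "known", "first", "only" and "open" are said of these compounds alone.

Measured so far in a functional assay on MGC-803 cells (Homo sapiens) for cytotoxicity, read by MTT assay, with a stated time of 48 h; a higher number here means a weaker inhibitor, a lower number a stronger inhibitor:
compound 1 `CC1=NN(C(=O)CSc2ccccn2)[C@@H](c2cc(Br)cc(Br)c2O)C1` gives 12300 nM
compound 2 `O=C(CSc1ccc(Br)cc1)N1N=C(c2cc3ccccc3oc2=O)C[C@@H]1c1ccccc1C(F)(F)F` gives 21300 nM

Going by the values given here, only two numbers are available for the series. Compound 1 and compound 2 lie within the usual scatter of each other, so these measurements do not separate them, and compound 1 cannot be ranked on this assay.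

The next compound to read is compound 3 `CC1=NN(C(=O)CSc2ccc(Br)cc2)[C@@H](c2cc(Br)cc(Br)c2O)C1`, which keeps the core of compound 1 and carries 4-bromophenyl in place of pyridin-2-yl on a sulfur. Among the compounds with values here, no pair of measured compounds differing in one place exists, so the series gives no direct measure of what this swap does. Within the data shown here, the only guide is the narrow spread of the two values, with compound 1 at 12300 nM and compound 2 at 21300 nM, and two compounds make a thin basis. No step beyond the scatter is expected in either direction, and the range is kept wide. The estimated 1.2-fold lower number from compound 1 to compound 3 (0.09 log units; within the scatter) therefore stays within the scatter. Compound 3 is estimated at 10000 nM within an expected range of 3500 nM to 30000 nM on this reading.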

Compound 3, half-maximal inhibitory concentration: 12800 nM
Compound 3: middle estimate off by 1.3-fold (0.11 log units), on the low side; measured number inside the range.
By their numbers in this assay, from the lowest: compounds 1, 3 and 2 (each within the scatter of the next).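

In this assay, the series now has its first direct measure at this position, with 4-bromophenyl in place of pyridin-2-yl on a sulfur: a 1.0-fold higher number from compound 1 to compound 3 (0.02 log units; within the scatter). On the core of compound 1, the two groups therefore read alike, although the one that leaves holds a ring nitrogen and 1 hydrogen-bond acceptor, while the one that enters is a ring of carbon only, carries a bromine and has 0 hydrogen-bond acceptors. Nothing at hand explains why the two groups read alike.

This is one pair on one core, both members of which place a six-membered aromatic ring on the sulfur, so it does not show how far the position's tolerance extends or whether it holds on other cores. A saturated group such as cyclohexyl, a longer chain ending in an amine or a carboxylic acid on the sulfur would test whether an aromatic ring is needed there at all.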